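Notes on an amine swap across two cores

This account rests on a few compounds, and the source may have more. Where it says the series, first, only, none or still open, it means among the compounds named here.

Measured so far, in a functional assay on the whole organism for agonist activity, with Mus musculus as the target; on this read-out higher numbers stand for an effect only at larger amounts of compound and lower numbers for an effect already at smaller amounts:
Compound 1 `COC(=O)N(C)CC#CCn1ccnc1` gives 4.5 mg/kg
Compound 2 `COC(=O)N(C)CC#CCN(C)C` gives 14.3 mg/kg
Compound 3 `O=C1NCCN1CC#CCn1ccnc1` gives 17.3 mg/kg

Compound 1 and compound 2 share a core and differ by dimethylamino in place of 1H-imidazol-1-yl on a saturated chain carbon bound to a triple-bonded carbon. In this assay this gave a 3.2-fold higher number from compound 1 to compound 2 (0.50 log units; beyond the scatter). Compound 3 carries another core, and how the core of compound 3 differs from the core of compound 1 is not broken down here. In this assay compound 3 and compound 2 lie within the scatter of each other, while compound 1 stands beyond the scatter from compound 3.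

Compound 4 `CN(C)CC#CCN1CCNC1=O` is not yet measured. It stands to compound 3 as compound 2 stands to compound 1: dimethylamino in place of 1H-imidazol-1-yl on a saturated chain carbon bound to a triple-bonded carbon. The place is described in the same words for both pairs, so this is the same change made on a second core, and it occurs twice in the series.

For compound 4 the expected step in this assay is a 2.9-fold higher number from compound 3 to compound 4 (0.46 log units; beyond the scatter), because the same change gave a 3.2-fold higher number from compound 1 to compound 2 (0.50 log units; beyond the scatter). Going by the values given here, since only one earlier instance of this change exists, and on a different core, the range is kept wide. The estimate for compound 4 in this assay is 50 mg/kg, expected to fall between 20 mg/kg and 130 mg/kg.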

Compound 4, dose for half-maximal effect: 9.7 mg/kg
Compound 4: the middle estimate sits 5.2-fold (0.71 log units) above what was measured; the measured number lies below the stated range.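

In this assay the swap on the second core gives a 1.8-fold lower number from compound 3 to compound 4 (0.25 log units; within the scatter), so on the core of compound 3 replacing 1H-imidazol-1-yl with dimethylamino leaves the dose within the usual scatter, whereas on the core of compound 1 the same swap moved the dose beyond it. The effect of this change therefore does not carry over in size from one core to the other in this series: the same change on two cores in this assay, a 3.2-fold higher number (0.50 log units; beyond the scatter) from compound 1 to compound 2 and a 1.8-fold lower number (0.25 log units; within the scatter) from compound 3 to compound 4, 5.7-fold (0.75 log units) apart, beyond the scatter of two such steps. Going by these compounds alone, with only two matched pairs, the data do not show which feature of the cores accounts for this gap, nor how the change would behave on any further core.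

Still open, going by these compounds, is whether a cyclic amine such as pyrrolidine or piperidine, placed on the same saturated chain carbon bound to a triple-bonded carbon, would behave differently on the two cores as dimethylamino does. On these data alone, a longer chain between the amine and the core is also open on both cores.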